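The source may hold more compounds than are shown below. What is called first, only, known or untested is meant among the compounds shown, and "the series" means these compounds.

In a functional assay on A549 cells (Homo sapiens) for antiproliferative activity, read by MTT assay, with a stated time of 48 h (on this read-out higher numbers stand for weaker inhibition and lower numbers for stronger inhibition), compound 1 `C#Cc1cccc(NC(=O)c2cc(NC(=O)CCCCCC(=O)NO)ccc2O)c1` gives 76200 nM while compound 2 `COc1cc(O)c(C(=O)Nc2ccc(F)c(Cl)c2)cc1NC(=O)CCCCCC(=O)NO` gives 24100 nM on the same read-out. Compound 2 thus holds the lower of the two numbers, and the gap between them lies beyond the scatter. Compound 3 `C#Cc1cccc(NC(=O)c2cc(NC(=O)CCCCCC(=O)NO)c(OC)cc2O)c1` departs from compound 2 in one place: 3-ethynylphenyl in place of 3-chloro-4-fluorophenyl on an amide-type nitrogen in words, 3-ethynylphenyl in place of 3-chloro-4-fluorophenyl on an amide-type nitrogen. Among the compounds with values here, no measured pair shows this change alone. Compound 1, which also carries 3-ethynylphenyl, stands at 76200 nM on the weaker side, so a small shift toward a higher number is expected in this assay rather than a large one. The expected move is a 1.5-fold higher number from compound 2 to compound 3 (0.17 log units; within the scatter) in this estimate, a step that would stay within the scatter. For compound 3 the estimated value is 36000 nM with an expected range from 14000 nM to 80000 nM across repeated measurements.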

Compound 3, half-maximal inhibitory concentration: 18400 nM
Beside the measured number, compound 3's estimate is 2.0-fold (0.29 log units) above it; the measured number falls inside the stated range.
By their numbers in this assay, from the lowest: compounds 3 and 2 (each within the scatter of the next); then compound 1.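

In this assay, the exchange of 3-chloro-4-fluorophenyl for 3-ethynylphenyl on the amide-type nitrogen, a 1.3-fold lower number from compound 2 to compound 3 (0.12 log units; within the scatter), stays within the scatter, so with the methoxy group in place these two aryl groups cannot be told apart on this read-out. The earlier compounds shown here offered no pair differing in one place; compound 3 supplies two, and the second isolates methoxy in place of hydrogen on an aromatic carbon, with a 4.1-fold lower number from compound 1 to compound 3 (0.62 log units; beyond the scatter), a modest step beyond the scatter. No information bears on why these numbers fall as they do.

On these data alone, whether the methoxy step also holds with 3-chloro-4-fluorophenyl on the amide-type nitrogen remains open. So does what ethoxy or an amine would give on that aromatic carbon in place of methoxy.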